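A Second Chloro on the Core of Compound 1

The compounds below may be only part of what the source reports. "The series", "measured", "known", "first", "only" and "open" are said of these compounds alone.

Within the data shown here, compound 1 `ClCc1cccc(Cn2cnc3ncnc(Cl)c32)c1` stands at the higher of the two numbers so far measured in a functional assay on LOX IMVI cells (Homo sapiens) for cytotoxicity, read by sulforhodamine B assay, with a stated time of 48 h; on this read-out lower numbers stand for stronger inhibition of growth and higher numbers for weaker inhibition of growth: in this assay compound 1 gives 14100 nM. Among the measured compounds shown here, the only other measured compound, compound 2 `ClCc1ccc(Cn2cnc3nc(Cl)nc(Cl)c32)cc1`, gives 3230 nM in this assay, a number beyond the scatter from that of compound 1; the two structures differ in more than one place, so the gap is not traced to a single change. Compound 3 `ClCc1cccc(Cn2cnc3nc(Cl)nc(Cl)c32)c1` awaits measurement. It differs from compound 1 by chloro in place of hydrogen on an aromatic carbon, a chloro in place of hydrogen on an aromatic carbon. For the measured compounds named here, no single-change step is known to set the size of this move, so the expectation leans on compound 2, whose value 3230 nM shows a core carrying two chloro groups reaching a lower number. The expected step is a 3.1-fold lower number from compound 1 to compound 3 (0.50 log units; beyond the scatter), downward. Compound 3 is estimated at 4500 nM, within a range from 1500 nM to 13000 nM.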

Compound 3, concentration for total growth inhibition: 790 nM
The estimate for compound 3 lay 5.7-fold (0.76 log units) above the measured number, outside the stated range (below it).
By their numbers in this assay, from the lowest: compound 3; then compound 2; then compound 1.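

In this assay, chloro in place of hydrogen on the aromatic carbon between two ring nitrogen atoms gives an 18-fold lower number from compound 1 to compound 3 (1.25 log units; beyond the scatter) on its own. The gap between compound 1 and compound 2 could not be traced to a single change, whereas this step ties a large shift in growth inhibition to this one position and this one group. The data offer no measured account of why the step is so large.

The compounds shown leave open what an amine or a methoxy group would do on this same carbon, since only hydrogen and chloro are seen there. From the compounds shown here alone, whether the step would keep its size with the chloromethyl group placed as it stands in compound 2 also remains open.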